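Sulfonyl aryl variation on a shared quinoline-free core description

The source may report more compounds than this note shows. Statements on the series, on what has been measured and on what is new or still open speak of the compounds shown alone.

Of the compounds shown here, three with the same shared core have been measured in a functional assay on the whole organism (strain Wistar) with Rattus norvegicus as the target; on this read-out higher numbers stand for an effect only at larger amounts of compound and lower numbers for an effect already at smaller amounts. Compound 1 `O=S(=O)(c1ccc(F)c(F)c1)c1cnc2c(F)cccc2c1-c1ccc(Cl)cc1` gives 3 mg/kg, compound 2 `O=S(=O)(c1ccc(F)c(Cl)c1)c1cnc2cc(F)ccc2c1-c1ccc(Cl)cc1` gives 30 mg/kg and compound 3 `O=S(=O)(c1cc(Cl)cc(Cl)c1)c1cnc2cc(F)ccc2c1-c1ccc(Cl)cc1` gives 30 mg/kg. Compound 3 stands level with compound 2 at the digits shown, the two together at the top of the series, while compound 1 stands well apart from both with the lowest number of the three.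

Going by the values given here, the one step that changes a single place, no change at the digits printed from compound 2 to compound 3 (within the scatter), exchanges one dihalogenated phenyl on the sulfonyl sulfur for another and leaves the read-out unchanged.

Compound 4 `O=S(=O)(c1ccc(F)c(F)c1)c1cnc2cc(F)ccc2c1-c1ccc(Cl)cc1` continues this line: 3,4-difluorophenyl in place of 3,5-dichlorophenyl on a sulfonyl sulfur. Among the compounds with values here, the only step that bears on it is the one from compound 2 to compound 3, which was flat, so a change of the halogen pattern on the sulfonyl phenyl is not expected to move the number beyond the scatter. Compound 1 carries the same 3,4-difluorophenyl but a differently placed fluorine on the shared core, so its low value is noted without being taken as a measured step towards compound 4. For compound 4 the expected result in this assay is 20 mg/kg, within 6 mg/kg to 60 mg/kg, an expected step of a 1.5-fold lower number from compound 3 to compound 4 (0.18 log units; within the scatter) from compound 3.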

Compound 4, minimum effective dose: 10 mg/kg
Beside the measured number, compound 4's estimate is 2.0-fold (0.30 log units) above it, and the stated range covers the measured number.
By their numbers in this assay, from the lowest: compound 1; then compound 4; then compounds 2 and 3 (each within the scatter of the next).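

In this assay the halogen pattern on the sulfonyl phenyl is not silent after all: 3,4-difluorophenyl in place of 3,5-dichlorophenyl on a sulfonyl sulfur gives a 3.0-fold lower number from compound 3 to compound 4 (0.48 log units; beyond the scatter) while the earlier exchange between two chlorine-bearing phenyls gave no change at the digits printed from compound 2 to compound 3 (within the scatter) and so nothing to read. Fluoro in place of chloro on an aromatic carbon gives a step of the same size, a 3.0-fold lower number from compound 2 to compound 4 (0.48 log units; beyond the scatter) and thus the 3,4-difluorophenyl of compound 4 stands apart from both chlorine-bearing phenyls, which stay level with each other. No measurement here explains why the difluoro pattern goes with the lower number.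

On these data alone, compound 1 at 3 mg/kg carries the same 3,4-difluorophenyl as compound 4 at 10 mg/kg and differs from it only in where the fluorine sits on the shared core, so how far the core fluorine and the sulfonyl aryl each contribute remains open. Also open, as far as these compounds go, is whether both fluorines are needed, and how an unsubstituted phenyl or a methoxyphenyl on the sulfonyl sulfur would read in this assay on this core.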